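Sulfur-linked chain in place of octyloxy on the shared core

The source may report more compounds than this note shows. Statements on the series, on what has been measured and on what is new or still open speak of the compounds shown alone.

Compound 2 `CCCCCCCCOc1cc(-c2ccccc2)c(-c2ccccc2)nn1` gives 104000 nM in an assay on microsomes from liver for inhibition of sterol O-acyltransferase 1 (Rattus norvegicus) (a lower number here means a stronger inhibitor, a higher number a weaker inhibitor), the lowest of the two numbers in hand. Compound 3 `CCCCCCCCCOc1cc(-c2ccccc2)c(-c2ccccc2)nn1` sits close by with 180000 nM in this assay, and the step of a 1.7-fold higher number from compound 2 to compound 3 (0.24 log units; within the scatter) stays within the scatter. Compound 1 `CCCCCC(=O)Nc1cc(-c2ccccc2)c(-c2ccccc2)nn1` reaches only a limit of this assay, > 300000 nM. The step of an at least 2.8-fold lower number from compound 1 to compound 2 (0.46 log units; beyond the scatter) is at least modest, but its size rests on the limit of > 300000 nM in this assay, at which 1 of the 3 values shown sits, and so carries no firm upper bound.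

Compound 4 `CCCCCCC[S+]([O-])c1cc(-c2ccccc2)c(-c2ccccc2)nn1` differs from compound 2 by a group of 9 heavy atoms (7 carbon, 1 oxygen, 1 sulfur; no ring) in place of a group of 9 heavy atoms (8 carbon, 1 oxygen; no ring), on an aromatic carbon. Going by the values given here, no measured step changes the group at this position in the same way. The step of an at least 2.8-fold lower number from compound 1 to compound 2 (0.46 log units; beyond the scatter) shows that the linking group on this carbon can move the number by a modest amount, while a 1.7-fold higher number from compound 2 to compound 3 (0.24 log units; within the scatter) shows the chain tail hardly matters. A step of modest size in either direction, or none beyond the scatter, is therefore the expectation for this assay, with a weaker number judged somewhat more likely given how few atoms are shared with the octyloxy linker.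

The estimate for compound 4 in this assay is 200000 nM, with a range from 60000 nM to 600000 nM.

The expected step from compound 2 to compound 4 is a 1.9-fold higher number from compound 2 to compound 4 (0.28 log units; within the scatter).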

Compound 4, half-maximal inhibitory concentration: 77000 nM
Beside the measured number, compound 4's estimate is 2.6-fold (0.41 log units) above it, within the range that was stated.
By their numbers in this assay, from the lowest: compounds 4, 2 and 3 (each within the scatter of the next, the first and the last beyond it). At a limit, above all of these: compound 1.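

The step of a 1.4-fold lower number from compound 2 to compound 4 (0.13 log units; within the scatter) shows that in this assay this aromatic carbon accepts the sulfur-linked group of compound 4 in place of octyloxy, with no shift beyond the scatter. The link on this carbon can therefore change from an ether oxygen to a sulfur bearing oxygen, at the same count of heavy atoms, and the number stays level. The step of an at least 3.8-fold lower number from compound 1 to compound 4 (0.59 log units; beyond the scatter) again favours a non-amide link, but it gives only a bound on size, as compound 1 stands at a limit: (the limit of > 300000 nM in this assay, at which 1 of the 4 values shown sits).

Still open, going by these compounds, is how a plain thioether or a sulfone would read on this carbon, and whether an amine link would fit as well. Also open, on these data alone, is whether a much shorter chain, or a carboxylic acid at the chain end, would move the number beyond the scatter.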